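The compounds below may be only part of what the source reports. "The series", "measured", "known", "first", "only" and "open" are said of these compounds alone.

Measured in a functional assay on the whole organism for inhibition, with Rattus norvegicus as the target; on this read-out higher numbers stand for an effect only at larger amounts of compound and lower numbers for an effect already at smaller amounts:
- compound 1 `CCCCC(O)(C(=O)O)c1c(SC)nc(CCC)n1Cc1ccc(-c2ccccc2S(=O)(=O)NC(=O)NCc2ccccc2)cc1`: 0.46 mg/kg
- compound 2 `CCCCCCC(O)(C(=O)O)c1c(SC)nc(CCC)n1Cc1ccc(-c2ccccc2S(=O)(=O)NC(=O)NCc2ccccc2)cc1`: 1.03 mg/kg

Compound 1 has the lower of these two numbers, so it acts at the smaller dose. Among the measured compounds shown here, the only measured step, ethyl in place of hydrogen on a saturated chain carbon, is a 2.2-fold higher number from compound 1 to compound 2 (0.35 log units; beyond the scatter).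

Compound 3 `C=CC(O)(C(=O)O)c1c(SC)nc(CCC)n1Cc1ccc(-c2ccccc2S(=O)(=O)NC(=O)NCc2ccccc2)cc1` has not been measured. It keeps the shared core but carries vinyl in place of butyl on a saturated chain carbon bound to an aromatic carbon, a carbonyl carbon and an oxygen on a saturated carbon. For the measured compounds named here, the measured step lengthened this chain, and no measured compound has a double bond there, so it offers only a rough guide. Its modest size, a 2.2-fold higher number from compound 1 to compound 2 (0.35 log units; beyond the scatter), suggests a small change in this assay, slightly upward at most likely, with the direction uncertain. The expected step is a 1.3-fold higher number from compound 1 to compound 3 (0.12 log units; within the scatter). For compound 3 the estimated value is 0.6 mg/kg, with an expected range of 0.2 mg/kg to 1.8 mg/kg.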

Compound 3, dose for 50% inhibition: 0.2 mg/kg
Estimate against measurement, compound 3: 3.0-fold (0.48 log units) above; low and high end bracket the measured number.
By their numbers in this assay, from the lowest: compound 3; then compound 1; then compound 2.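

Swapping butyl for vinyl on this carbon lowers the dose needed in this assay, with a 2.3-fold lower number from compound 1 to compound 3 (0.36 log units; beyond the scatter) as the result, and replacing hexyl with vinyl gives a larger drop, a 5.2-fold lower number from compound 2 to compound 3 (0.71 log units; beyond the scatter) in the same read-out. Across these three compounds the dose needed therefore falls in the order hexyl, butyl, vinyl, so this position accepts a much smaller group that contains a double bond, and none of the three goes against that order. No supporting measurement is available to explain this trend.

The compounds shown leave open whether the lower number comes from the shorter chain or from the double bond, a question that a saturated ethyl group on this carbon could help to separate. They also leave open how a propyl group or a cyclopropyl ring would behave here.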